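This account rests on a few compounds, and the source may have more. Where it says the series, first, only, none or still open, it means among the compounds named here.

Three compounds that share one core and differ only in the aryl group attached to it have been tested in a functional assay on SGC-7901 cells (Homo sapiens) for antiproliferative activity, read by MTT assay, with a stated time of 72 h; a lower number here means a stronger inhibitor, a higher number a weaker inhibitor. Compound 1 `COc1cc(-n2cnc3ccc(-c4ccccc4Cl)cc32)cc(OC)c1OC`, carrying 2-chlorophenyl, gives only a limit of the assay, > 10000 nM. Compound 2 `COc1cc(-n2cnc3ccc(-c4ccc(C(F)(F)F)cc4)cc32)cc(OC)c1OC`, with 4-(trifluoromethyl)phenyl, gives 890 nM, and compound 3 `COc1cc(-n2cnc3ccc(-c4cccc(F)c4)cc32)cc(OC)c1OC`, with 3-fluorophenyl, gives 2490 nM. Compound 3 therefore holds the higher of the two actual numbers, and the gap between them is a 2.8-fold higher number from compound 2 to compound 3 (0.45 log units; beyond the scatter), a modest step. The steps measured against the limit are an at least 4.0-fold lower number from compound 1 to compound 3 (0.60 log units; beyond the scatter), at least modest, and an at least 11-fold lower number from compound 1 to compound 2 (1.05 log units; beyond the scatter), large.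

Compound 4 `COc1cc(-n2cnc3ccc(-c4cccc([N+](=O)[O-])c4)cc32)cc(OC)c1OC` differs from compound 3 in one place, with nitro in place of fluoro on an aromatic carbon, meta to a large group: nitro in place of fluoro on an aromatic carbon. Among the compounds with values here, no tested compound carries nitro, so the direction of the change stays open. Only a 2.8-fold higher number from compound 2 to compound 3 (0.45 log units; beyond the scatter) joins two actual numbers, and it is modest, so a step of no more than that size is expected in this assay, most likely none beyond the scatter. The expected step is a 1.4-fold lower number from compound 3 to compound 4 (0.14 log units; within the scatter). For compound 4 the estimated value is 1800 nM, with an expected range from 550 nM to 7000 nM.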

Compound 4, half-maximal inhibitory concentration: 380 nM
Beside the measured number, compound 4's estimate is 4.7-fold (0.68 log units) above it, outside the stated range (below it).
By their numbers in this assay, from the lowest: compound 4; then compound 2; then compound 3. At a limit, above all of these: compound 1.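

In this assay, within the data shown here, the earlier compounds changed the whole aryl group, so they could not show what a single substituent at one ring position contributes. Here the ring and the position, meta to a large group, stay the same and only the substituent changes, giving a 6.6-fold lower number from compound 3 to compound 4 (0.82 log units; beyond the scatter), so this one position alone can shift the result beyond the scatter. The change also carries the series past its previous best, with a 2.3-fold lower number from compound 2 to compound 4 (0.37 log units; beyond the scatter), which makes compound 4 the strongest inhibitor of the four shown, while the widest gap, an at least 26-fold lower number from compound 1 to compound 4 (1.42 log units; beyond the scatter), is only a bound, because one end of it is a limit of the assay and not a number: the limit of > 10000 nM in this assay, at which 1 of the 4 values shown sits.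

With only fluoro and nitro compared at this position, the compounds shown do not say whether other groups there, such as an amine, a nitrile or a carboxylic acid, would give a lower or a higher number. They also leave open why nitro gives a lower number than fluoro, and whether nitro would do the same on another carbon of the ring.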